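A few compounds are considered here, and "the series" means these few. Any claim that something is new, unique, unknown or untested is made for them only; others in the source may bear on it.

In a functional assay on K562 cells (Homo sapiens) for inhibition (a higher number here means a weaker inhibitor, a lower number a stronger inhibitor), three compounds have been measured so far. Compound 1 (`CCOc1ccc(Br)cc1-c1cc(Nc2cccc(C#N)c2)nc(N)n1`) gives 350 nM, compound 3 (`Cc1ccc(Cl)cc1-c1cc(Nc2cccc(Br)c2)nc(N)n1`) gives 200 nM, and compound 2 (`Cc1ccc(Cl)cc1-c1cc(Nc2ccc(Br)cc2)nc(N)n1`) gives 60 nM, the lowest of the three numbers and so the strongest inhibitor among them.

Compound 4 (`Cc1ccc(Cl)cc1-c1cc(Nc2ccc(C(F)(F)F)cc2)nc(N)n1`) has not been measured yet. It differs from compound 2 in a single place: trifluoromethyl in place of bromo on an aromatic carbon. The rest of the molecule stays the same, so any change in the number can be traced to this one swap.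

Going by the values given here, only one measured step offers guidance, and only indirectly. Putting 3-bromophenyl in place of 4-bromophenyl gives a 3.3-fold higher number from compound 2 to compound 3 (0.52 log units; beyond the scatter). This shows that a change on this ring can move the number by a modest amount, but that step moves a group rather than replacing it. Among the compounds with values here, no measured pair shows what replacing bromo does here, so the direction is uncertain.

With compound 2 at the low end of the measured values at 60 nM, a small rise seems more likely than a further drop. The expected change is a 1.7-fold higher number from compound 2 to compound 4 (0.22 log units; within the scatter), which may not clear the usual scatter. In this assay, the estimated value for compound 4 is 100 nM, with an expected range from 35 nM to 300 nM.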

Compound 4, half-maximal inhibitory concentration: 140 nM
Beside the measured number, compound 4's estimate is 1.4-fold (0.15 log units) below it; the range from low to high includes it.
By their numbers in this assay, from the lowest: compound 2; then compounds 4, 3 and 1 (each within the scatter of the next, the first and the last beyond it).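

In this assay, going by these compounds alone, trifluoromethyl in place of bromo gives a 2.3-fold higher number from compound 2 to compound 4 (0.37 log units; beyond the scatter), the first reading of what replacing the group does, and it shows that this place on the ring responds to a new group as well as to the move of bromo that gave a 3.3-fold higher number from compound 2 to compound 3 (0.52 log units; beyond the scatter) earlier. The step is modest even though the entering group has four heavy atoms and the leaving one has a single heavy atom, so the larger group is accepted here, with compound 4 still giving a value of 140 nM in the same assay, while bromo remains the better of the two groups at this place. Nothing measured here accounts for the size or direction of this step.

Going by these compounds, it remains open whether an amine or a carboxylic acid on this aromatic carbon would hold the number near the value of compound 2 at 60 nM or move it much further. Also open, on these data alone, is how trifluoromethyl would fare at the place that bromo holds in compound 3, and whether the preference seen for bromo would carry over to a different group there.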